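This account rests on a few compounds, and the source may have more. Where it says the series, first, only, none or still open, it means among the compounds named here.

Three compounds built on a shared core were tested in a functional assay on HeLa cells (Homo sapiens) for antiproliferative activity, read by CCK-8 assay, with a stated time of 72 h, tested at 8 uM; on this read-out lower numbers stand for a weaker effect and higher numbers for a stronger effect at the one concentration tested. Compound 1 `Nc1ccccc1NC(=O)c1ccc(CSC(=S)N2CCN(c3ccc(F)cc3)CC2)cc1` gives 64.5%, the second highest of the three numbers. Compound 2 `Nc1ccccc1NC(=O)c1ccc(CSC(=S)N2CCCC2)cc1` gives 77.8%, which lies beyond the scatter above compound 1, while compound 3 `Nc1ccccc1NC(=O)c1ccc(CSC(=S)N2CCc3cc([N+](=O)[O-])ccc32)cc1` gives 43.6%, which lies beyond the scatter below compound 1. Compound 4 `Nc1ccccc1NC(=O)c1ccc(CSC(=S)N2CCN(c3cnccn3)CC2)cc1` has not yet been measured in this assay. It differs from compound 1 in one place: pyrazin-2-yl in place of 4-fluorophenyl on an amine nitrogen in a ring. Among the measured compounds shown here, no measured pair shows the effect of such a change, so a step from compound 1 to compound 4 of modest size, at most a little downward and possibly within the scatter, is expected, namely a number 6.5 percentage points lower from compound 1 to compound 4 (within the scatter). Compound 4 is therefore estimated at 58%, with a likely range from 40% to 75%.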

Compound 4, a percentage reported as inhibition, at one concentration (the size of the read-out at that concentration, not a potency): 76.9%
Beside the measured number, compound 4's estimate is 18.9 percentage points below it, and the stated range ends below it.
By their numbers in this assay, from the lowest: compound 3; then compound 1; then compounds 4 and 2 (each within the scatter of the next).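

In this assay, among the compounds shown here, replacing 4-fluorophenyl with pyrazin-2-yl on the ring amine nitrogen gives a number 12.4 percentage points higher from compound 1 to compound 4 (beyond the scatter), the first single-place change in this set that can be read. This position therefore tolerates a switch from a carbon-only aromatic ring to one with two ring nitrogens, and the read-out responds to that switch. Nothing measured here explains the step. One pair cannot separate the loss of fluorine from the gain of ring nitrogens. Plain phenyl or pyridin-2-yl at this position would leave that question open no longer.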